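Halogen exchange on the amide of the shared core

The source may report more compounds than this note shows. Statements on the series, on what has been measured and on what is new or still open speak of the compounds shown alone.

Compound 1 `CCN1CCN(c2cc(C)c3cc(NC(=O)c4ccc(F)cc4)ccc3n2)CC1` is the starting point of this set; in a functional assay on MCF7 cells (Homo sapiens) for antiproliferative activity, read by MTT assay, with a stated time of 72 h (a higher number here means a weaker inhibitor, a lower number a stronger inhibitor), compound 1 gives 4030 nM. Compound 2 `CCN1CCN(c2cc(C)c3cc(NC(=O)c4ccc(Br)cc4)ccc3n2)CC1` gives 5940 nM, and compound 3 `CCN1CCN(c2cc(C)c3cc(NC(=O)c4ccc(F)c(F)c4)ccc3n2)CC1` gives 5230 nM. Compound 3 stands second highest of the three numbers: its nearest neighbour is compound 2, a 1.1-fold lower number from compound 2 to compound 3 (0.06 log units; within the scatter), and its furthest is compound 1, a 1.3-fold higher number from compound 1 to compound 3 (0.11 log units; within the scatter). All three numbers thus sit within the scatter of one another, and no order among them can be read.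

Compound 4 `CCN1CCN(c2cc(C)c3cc(NC(=O)c4ccc(Cl)c(Cl)c4)ccc3n2)CC1` differs from compound 3 in one place: 3,4-dichlorophenyl in place of 3,4-difluorophenyl on a carbonyl carbon. Within the data shown here, no measured step replaces one halogen pair with another in this way. The nearest precedents are bromo in place of fluoro, a 1.5-fold higher number from compound 1 to compound 2 (0.17 log units; within the scatter), and fluoro in place of hydrogen, a 1.3-fold higher number from compound 1 to compound 3 (0.11 log units; within the scatter); both stayed within the scatter. Nothing in these numbers points to a move in this assay in either direction for the present exchange.

Compound 4 is therefore expected to show a step of a 1.1-fold higher number from compound 3 to compound 4 (0.02 log units; within the scatter), which is no change beyond the scatter. The estimate for compound 4 in this assay is 5500 nM, with a range of 2500 nM to 12000 nM.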

Compound 4, half-maximal inhibitory concentration: 1380 nM
Estimate against measurement, compound 4: 4.0-fold (0.60 log units) above, outside the stated range (below it).
By their numbers in this assay, from the lowest: compound 4; then compounds 1, 3 and 2 (each within the scatter of the next).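

Notes on the amide aryl group: on a carbonyl carbon whose other neighbours are amide-type nitrogen, the halogen exchanges among compounds 1, 2 and 3 gave no separation, but in this assay 3,4-dichlorophenyl in place of 3,4-difluorophenyl gives a 3.8-fold lower number from compound 3 to compound 4 (0.58 log units; beyond the scatter), so the number at this position can move beyond the scatter with the aryl group alone. Compound 4 also stands apart from the two compounds carrying a single halogen, with a 4.3-fold lower number from compound 2 to compound 4 (0.63 log units; beyond the scatter) and a 2.9-fold lower number from compound 1 to compound 4 (0.47 log units; beyond the scatter), which makes it the strongest inhibitor of the four here, though compound 3 goes against any reading that two halogens on the ring are enough. No measurement in hand bears on what lies behind this step.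

The compounds shown leave open whether the lower number needs both chlorines or would persist with 4-chlorophenyl alone on the carbonyl carbon. They also leave open whether chlorine itself matters or whether a non-halogen pair, as in 3,4-dimethylphenyl, would give a similar step in this assay.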